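Cytotoxicity notes: nitrophenyl variant of the dichlorophenyl amide

This account rests on a few compounds, and the source may have more. Where it says the series, first, only, none or still open, it means among the compounds named here.

Measured so far:
Compound 1 `CCOC(=O)CCCCCOc1cccc(CN(C(=O)c2ccc(-c3cc(OC)ccc3F)cc2)C(C)C)c1` in an ADME assay on BJ cells (Homo sapiens) for cytotoxicity, read by CellTiter-Glo and resazurin assay, with a stated time of 72 h (a lower number here means that less compound is needed, a higher number that more compound is needed for the effect), reads > 26000 nM, a limit of the assay.
Compound 2 `CCOC(=O)CCCCCOc1cccc(CN(C(=O)c2ccc(-c3ccc(Cl)c(Cl)c3)cc2)C(C)C)c1` in this assay reads > 26000 nM, also a limit of the assay.

Compound 2 stands at the assay limit. Both values shown sit at the limit of > 26000 nM in this assay, at which 2 of the 2 values shown sit. The step that the two limits leave unreadable from compound 1 to compound 2 is for that reason not readable in size. The next change is 3-nitrophenyl in place of 3,4-dichlorophenyl on an aromatic carbon, giving compound 3 `CCOC(=O)CCCCCOc1cccc(CN(C(=O)c2ccc(-c3cccc([N+](=O)[O-])c3)cc2)C(C)C)c1`. Among the compounds with values here, no measured step bears readably on this change. With both earlier values at the limit, compound 3 is expected to give 30000 nM (range 15000 nM to 80000 nM). The step that the limit leaves unreadable from compound 2 to compound 3 is expected to stay within the scatter, most likely again reported only as a limit.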

Compound 3, half-maximal effective concentration: < 1.3 nM
Compound 3 was reported as a limit; the forecaster's own chance of this, stated with the estimate: 80%; middle value at least 23000-fold (4.36 log units) from the limit.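

Placing 3-nitrophenyl on this aromatic carbon gives an at least 20000-fold lower number from compound 2 to compound 3 (4.30 log units; beyond the scatter) and an at least 20000-fold lower number from compound 1 to compound 3 (4.30 log units; beyond the scatter) in this assay, so this position is not silent in the series, which the earlier pair could not show, as the step between those two cannot be read. Compound 3 reads < 1.3 nM, a limit of the assay. From the compounds shown here alone, the full size of both steps therefore remains unknown.

Going by these compounds, it remains open whether the nitro group itself carries this effect, or whether an amine in its place would read alike. A carboxylic acid in place of the ester is likewise untested in the compounds shown.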